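A few compounds are considered here, and "the series" means these few. Any claim that something is new, unique, unknown or untested is made for them only; others in the source may bear on it.

Measured so far:
Compound 1 `Cc1ccc(C(=O)/C=C/c2cccc(Br)c2Oc2c([N+](=O)[O-])cc(C(F)(F)F)cc2[N+](=O)[O-])cc1` gives 0.55 ug/mL
Compound 2 `O=C(/C=C/c1cc(Br)cc(Br)c1Oc1c([N+](=O)[O-])cc(C(F)(F)F)cc1[N+](=O)[O-])c1ccc(Cl)cc1` gives 6.76 ug/mL

In a functional assay on MCF7 cells (Homo sapiens) for antiproliferative activity, read by MTT assay, with a stated time of 48 h (on this read-out higher numbers stand for weaker inhibition and lower numbers for stronger inhibition), compound 2 at 6.76 ug/mL holds the higher of the two numbers, and its gap to compound 1 lies beyond the scatter. Compound 3 `O=C(/C=C/c1cccc(Br)c1Oc1c([N+](=O)[O-])cc(C(F)(F)F)cc1[N+](=O)[O-])c1ccc(Cl)cc1` comes from compound 2 by one change hydrogen in place of bromo on an aromatic carbon with hydrogen in place of bromo on an aromatic carbon. Within the data shown here, no measured step isolates this change. Among the measured compounds shown here, the expectation rests on compound 1 with 0.55 ug/mL as the only lower number. A drop toward stronger inhibition is expected, an estimated 3.4-fold lower number from compound 2 to compound 3 (0.53 log units; beyond the scatter) that would lie beyond the scatter. Compound 3 is estimated at 2 ug/mL with a range from 0.5 ug/mL to 7.5 ug/mL in this assay once measured.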

Compound 3, half-maximal inhibitory concentration: 4.74 ug/mL
For compound 3 the middle estimate is 2.4-fold (0.37 log units) below the measured one; the range from low to high includes it.
By their numbers in this assay, from the lowest: compound 1; then compounds 3 and 2 (each within the scatter of the next).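

In this assay hydrogen in place of bromo, on the aromatic carbon meta to a 2-((4-chlorophenyl)carbonyl)ethenyl group, gives a 1.4-fold lower number from compound 2 to compound 3 (0.15 log units; within the scatter) and so leaves this position without a readable effect. Chloro in place of methyl on an aromatic carbon gives an 8.6-fold higher number from compound 1 to compound 3 (0.94 log units; beyond the scatter) and is the only single change here that lies beyond the scatter. No measured evidence bears on either step.

Open, on these data alone, is how larger or charged groups, such as an amine or a carboxylic acid, would read at the bromo position. Also open, as far as these compounds go, is whether the chloro and methyl step holds with this bromo group present.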